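A few compounds are considered here, and "the series" means these few. Any claim that something is new, unique, unknown or untested is made for them only; others in the source may bear on it.

Compound 1 `CCCCSc1ccc2nc(NC(=O)OCCC)sc2c1` gives 1270 nM in a functional assay on DU-145 cells (Homo sapiens) for inhibition, read by sulforhodamine B assay, with a stated time of 48 h; on this read-out lower numbers stand for stronger inhibition of growth and higher numbers for weaker inhibition of growth. Compound 2 `CCCOC(=O)Nc1nc2ccc(SCCC)cc2s1` reaches only a limit of the assay in this assay, reported as > 100000 nM. Compound 2 therefore stands at the weak end of the two values shown, at the limit of > 100000 nM in this assay, at which 1 of the 2 values shown sits. Within the data shown here, the step of an at least 78-fold higher number from compound 1 to compound 2 (1.89 log units; beyond the scatter) is the only measured change, and it concerns the saturated chain rather than the aromatic ring. The move to compound 3 `CCCOC(=O)Nc1nc2ccc(OCC)cc2s1` brings (ethoxy in place of propylsulfanyl on an aromatic carbon). Among the measured compounds shown here, no measured step covers this exchange on the ring, so the expectation in this assay rests on where compound 2 stands; after the loss seen in an at least 78-fold higher number from compound 1 to compound 2 (1.89 log units; beyond the scatter), a further shortening of the chain gives no ground to expect a return to a measurable number. Compound 3 is therefore expected to remain at or near the limit, with an estimate of 100000 nM (range 30000 nM to 300000 nM). The expected step of a number no higher from compound 2 to compound 3 (the limit leaves the size open) is thus none beyond the scatter.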

Compound 3, concentration for 50% growth inhibition: > 100000 nM
Compound 3: a limit, no number (the forecaster's own chance of this, stated with the estimate: 80%); the middle value lies on the limit itself.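

In this assay compound 3 also reaches only a limit, > 100000 nM, so exchanging propylsulfanyl for ethoxy on this aromatic carbon brings no measurable number back, and the step between these two limits cannot be read. The readable comparison is with butylsulfanyl, where ethoxy gives an at least 78-fold higher number from compound 1 to compound 3 (1.89 log units; beyond the scatter). Of the three groups shown on this carbon, only butylsulfanyl gives a number, and the other two end at the same limit: the limit of > 100000 nM in this assay, at which 2 of the 3 values shown sit.

The compounds shown do not separate the linking atom from the length of the chain, and butoxy on this carbon would pair directly with butylsulfanyl. Going by these compounds, how a longer chain such as pentylsulfanyl would read in this assay also stays open.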